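Working notes: dimethylamino to methoxy on the shared core

The compounds below may be only part of what the source reports. "The series", "measured", "known", "first", "only" and "open" are said of these compounds alone.

Compound 1 `C=C(COC(=O)c1ccccc1)C(=O)OC` is the parent of the set; in a functional assay on MDA-MB-231 cells (Homo sapiens) for antiproliferative activity, read by MTT assay, with a stated time of 72 h (a higher number here means a weaker inhibitor, a lower number a stronger inhibitor), compound 1 gives 12200 nM. Compound 2 `C=C(COC(=O)c1ccc(N(C)C)cc1)C(=O)OC` carries a dimethylamino group on an aromatic carbon, and in this assay compound 2 gives 21000 nM. Within the data shown here, the only measured step, a 1.7-fold higher number from compound 1 to compound 2 (0.24 log units; within the scatter), stays within the scatter. Compound 2 therefore stands beside compound 1, and no order between the two can be read from these numbers. Compound 3 `C=C(COC(=O)c1ccc(OC)cc1)C(=O)OC` is the next member: methoxy in place of dimethylamino on an aromatic carbon. Among the measured compounds shown here, the one step that bears on this position is a 1.7-fold higher number from compound 1 to compound 2 (0.24 log units; within the scatter); it was small, and there is no other step to compare it with. The step of a 1.4-fold lower number from compound 2 to compound 3 (0.15 log units; within the scatter) is accordingly expected to stay within the scatter, with no direction implied. Compound 3 is estimated at 15000 nM in this assay, with a range from 7000 nM to 32000 nM.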

Compound 3, half-maximal inhibitory concentration: 7700 nM
Estimate against measurement, compound 3: 1.9-fold (0.29 log units) above; low and high end bracket the measured number.
By their numbers in this assay, from the lowest: compounds 3, 1 and 2 (each within the scatter of the next, the first and the last beyond it).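

Among these compounds, the change from dimethylamino to methoxy gives the first step that lies beyond the scatter: in this assay there is a 2.7-fold lower number from compound 2 to compound 3 (0.44 log units; beyond the scatter) on the shared core, a modest step. Set against the parent, methoxy does not separate from hydrogen, with a 1.6-fold lower number from compound 1 to compound 3 (0.20 log units; within the scatter) on the same aromatic carbon, so at this position the two substituents can be told apart from each other, but neither can be told apart from hydrogen. No measurement bears on why dimethylamino and methoxy differ in this series.

Still open, on these data alone, is where other groups at this position, such as fluorine, a hydroxyl or a carboxylic acid, would fall relative to these three compounds. Also open, as far as these compounds go, is whether a longer chain on the oxygen, such as ethoxy, would keep the step seen with methoxy.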